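Swapping a nitrooxyphenyl for a dichlorophenyl: cytotoxicity outlook

The source may report more compounds than this note shows. Statements on the series, on what has been measured and on what is new or still open speak of the compounds shown alone.

Compound 1 `COc1ccc(/C=N/NC(=O)Nc2ccc(Oc3ccnc(-c4nncn4CCN(C)C)c3)c(F)c2)c(OC)c1OC` gives "not determined" (no result reported) in an ADME assay on WI-38 cells (Homo sapiens) for cytotoxicity, read by MTT assay, with a stated time of 72 h (a lower number here means a stronger inhibitor, a higher number a weaker inhibitor), so no result is reported for it. Within the data shown here, compound 2 `CN(C)CCn1cnnc1-c1cc(Oc2ccc(NC(=O)N/N=C/c3ccccc3O[N+](=O)[O-])cc2F)ccn1` is the only compound with a number: in this assay compound 2 gives 6860 nM, so it stands alone and offers no ranking against other compounds. Compound 3 `CN(C)CCn1cnnc1-c1cc(Oc2ccc(NC(=O)N/N=C/c3cccc(Cl)c3Cl)cc2F)ccn1` differs from compound 2 by 2,3-dichlorophenyl in place of 2-(nitrooxy)phenyl on a carbon with a double bond to nitrogen. Among the measured compounds shown here, no step between measured compounds covers this change, so its size is unknown from the data. Compound 3 is expected to give 5500 nM in this assay, with a range of 2000 nM to 15000 nM. This estimate means a step of a 1.2-fold lower number from compound 2 to compound 3 (0.10 log units; within the scatter), expected to stay within the usual scatter.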

Compound 3, half-maximal inhibitory concentration: 6130 nM
The estimate for compound 3 lay 1.1-fold (0.05 log units) below the measured number, and the stated range covers the measured number.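

In this assay, among these compounds, 2,3-dichlorophenyl in place of 2-(nitrooxy)phenyl on a carbon with a double bond to nitrogen gives a 1.1-fold lower number from compound 2 to compound 3 (0.05 log units; within the scatter) and so provides the first readable comparison at this position, since compound 1 has no reported result. The read-out stays within the usual scatter even though the entering group has no hydrogen-bond acceptors and the leaving group has them. No measurement given here accounts for this outcome. Still open, on these data alone, is whether an amine or a carboxylic acid on the phenyl ring at this position would move the number beyond the scatter.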